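The source may hold more compounds than are shown below. What is called first, only, known or untested is meant among the compounds shown, and "the series" means these compounds.

Compound 1 `COc1ccccc1-c1ccc2ncn(-c3cc(OC)c(OC)c(OC)c3)c2c1` is one of three compounds that share a core and differ only in the group attached to one aromatic carbon of that core. In a functional assay on MCF7 cells (Homo sapiens) for antiproliferative activity, read by MTT assay, with a stated time of 72 h (a higher number here means a weaker inhibitor, a lower number a stronger inhibitor), compound 1 gives 1750 nM, the second highest of the three numbers. Compound 2 `COc1cc(-n2cnc3ccc(-c4cc(F)ccc4F)cc32)cc(OC)c1OC` gives 6420 nM, and the change a 3.7-fold higher number from compound 1 to compound 2 (0.56 log units; beyond the scatter) is a modest weakening. Compound 3 `COc1cc(-n2cnc3ccc(-c4cccc(O)c4)cc32)cc(OC)c1OC` gives 350 nM, and the change a 5.0-fold lower number from compound 1 to compound 3 (0.70 log units; beyond the scatter) is a modest gain; between those two, the step of an 18-fold lower number from compound 2 to compound 3 (1.26 log units; beyond the scatter) is large.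

Compound 4 `COc1cc(-n2cnc3ccc(-c4cccc(C)c4C)cc32)cc(OC)c1OC` has not been measured. It differs from compound 1 as follows: 2,3-dimethylphenyl in place of 2-methoxyphenyl on an aromatic carbon. Among the compounds with values here, the entering group carries 0 hydrogen-bond donors and 0 hydrogen-bond acceptors, and no measured compound carries it, so neither of the steps from compound 1 matches it closely. The two steps from compound 1 point in opposite directions, and the gain seen for compound 3 350 nM came with a hydroxyl donor that compound 4 lacks.

For compound 4 the expected step is a 1.4-fold higher number from compound 1 to compound 4 (0.15 log units; within the scatter), small and of uncertain direction. Compound 4 is therefore estimated at 2500 nM, with a range from 800 nM to 8000 nM.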

Compound 4, half-maximal inhibitory concentration: 2150 nM
For compound 4 the middle estimate is 1.2-fold (0.07 log units) above the measured one; low and high end bracket the measured number.
By their numbers in this assay, from the lowest: compound 3; then compounds 1 and 4 (each within the scatter of the next); then compound 2.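

In this assay, putting the all-carbon 2,3-dimethylphenyl in place of 2-methoxyphenyl gives a 1.2-fold higher number from compound 1 to compound 4 (0.09 log units; within the scatter), so at this aromatic carbon, losing the hydrogen-bond acceptor counted on the leaving group brings no readable change. The two other new steps lie beyond the scatter, a 6.1-fold higher number from compound 3 to compound 4 (0.79 log units; beyond the scatter) and a 3.0-fold lower number from compound 2 to compound 4 (0.48 log units; beyond the scatter), which leaves 2,3-dimethylphenyl level with 2-methoxyphenyl, short of the gain seen with 3-hydroxyphenyl and clear of the weakening seen with 2,5-difluorophenyl. No measurement at hand explains these differences.

Within the data shown here, whether the hydroxyl group of compound 3 matters in itself remains open, since no other compound here carries a hydroxyl group. A plain phenyl ring, or a phenyl ring carrying an amine or a carboxylic acid, would help test this.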